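This account rests on a few compounds, and the source may have more. Where it says the series, first, only, none or still open, it means among the compounds named here.

In a functional assay on BV-2 cells (Mus musculus) for inhibition, read by Griess assay, with stated times of 3 h and 24 h (on this read-out lower numbers stand for stronger inhibition and higher numbers for weaker inhibition), two compounds have been measured. Compound 1 `COc1ccc(CS(=O)(=O)/C=C/c2ccc(O)c(O)c2)cc1` gives 11900 nM. Compound 2 `[O-][S+](/C=C/c1ccc(O)c(O)c1)Cc1ccccc1` gives 50300 nM, which is the higher of the two numbers, and the gap between it and the number of compound 1 lies beyond the usual scatter of this read-out. Going by the values given here, no single-point step joins these two compounds, as they differ in more than one place, so their values are reported side by side without a counted difference.

Compound 3 `[O-][S+](/C=C/c1ccc(O)c(O)c1)Cc1ccc(Cl)cc1` has not yet been measured in this assay. It follows from compound 2 by one change, (chloro in place of hydrogen on an aromatic carbon), that is, chloro in place of hydrogen on an aromatic carbon. Among the compounds with values here, the records give no step of this kind between measured compounds, so the size of the step from compound 2 to compound 3 is estimated rather than read: the step of a 1.7-fold lower number from compound 2 to compound 3 (0.22 log units; within the scatter) is expected to be modest, toward a lower number, and it may well stay within the scatter. Compound 3 is therefore estimated at 30000 nM, with a range from 10000 nM to 90000 nM.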

Compound 3, half-maximal inhibitory concentration: 14000 nM
Beside the measured number, compound 3's estimate is 2.1-fold (0.33 log units) above it; the measured number falls inside the stated range.
By their numbers in this assay, from the lowest: compounds 1 and 3 (each within the scatter of the next); then compound 2.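

In this assay, going by these compounds alone, chloro in place of hydrogen on an aromatic carbon, para to a large group, gives a 3.6-fold lower number from compound 2 to compound 3 (0.56 log units; beyond the scatter) and so supplies the first counted single-point step in this set. The two compounds measured earlier differ in more than one place, so they could not show what any one position contributes; this result shows that a single chlorine at this place on the six-membered aromatic ring moves the number beyond the scatter, toward stronger inhibition. Nothing in the data at hand accounts for the size or direction of this step.

Since only one substituent at one place is shown, it remains open whether a fluoro group, a nitrile or an amine at the same place would move the number in the same direction, and whether chloro would do so elsewhere on that ring. As far as these compounds go, it is also open whether the same change would give a step of similar size on the core of compound 1, with its sulfonyl link.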